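Imidazolylmethyl anilines: cytotoxicity notes on a benzyl variation

A few compounds are considered here, and "the series" means these few. Any claim that something is new, unique, unknown or untested is made for them only; others in the source may bear on it.

Measured compounds:
compound 1, `c1ccc(-c2ccc(Cn3cncc3CNc3cccc(-c4ccccc4)c3)cc2)cc1`, 10000 nM in a toxicity assay on NIH3T3 cells (Mus musculus) for cytotoxicity, read by resazurin assay; on this read-out higher numbers stand for an effect only at larger amounts of compound and lower numbers for an effect already at smaller amounts
compound 2, `COC(=O)c1ccc(NCc2cncn2Cc2ccc(C(C)(C)C)cc2)cc1-c1ccccc1`, "not determined" (no result reported) in this assay

Compound 2, `COC(=O)c1ccc(NCc2cncn2Cc2ccc(C(C)(C)C)cc2)cc1-c1ccccc1`, stands at "not determined" (no result reported) in this assay; the assay was run but no value was returned, so compound 2 gives no anchor of its own. Compound 1, `c1ccc(-c2ccc(Cn3cncc3CNc3cccc(-c4ccccc4)c3)cc2)cc1`, gives 10000 nM in this assay and is the only measured point in the series.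

Compound 3, `COC(=O)c1ccc(NCc2cncn2Cc2ccc(-c3ccccc3)cc2)cc1-c1ccccc1`, differs from compound 2 by phenyl in place of tert-butyl on an aromatic carbon. Among the measured compounds shown here, no step between measured compounds exists for this change, so its size cannot be read from the data. In this assay no shift beyond the scatter is expected from this change, since compound 3 carries the same 4-phenylphenyl as compound 1.

For compound 3 a value near 10000 nM in this assay is expected, within 3000 nM to 30000 nM, because compound 1 gives 10000 nM with the same 4-phenylphenyl.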

Compound 3, half-maximal effective concentration: > 1000 nM
Compound 3 gave a limit, no number (the forecaster's own chance of this, stated with the estimate: 40%); the middle value lies beyond the limit too.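

In this assay compound 3 gives > 1000 nM, which is a limit and not a number. Among the compounds shown here, no step between compound 1 and compound 3 can be read from it. The compounds shown leave open what size of shift, if any, methoxycarbonyl in place of hydrogen or phenyl in place of tert-butyl brings in this assay.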